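The source may report more compounds than this note shows. Statements on the series, on what has been measured and on what is new or still open speak of the compounds shown alone.

Measured in a functional assay on HCT-116 cells (Homo sapiens) for cytotoxicity, read by MTT assay, with a stated time of 72 h; a lower number here means a stronger inhibitor, a higher number a weaker inhibitor:

Compound 1 `CC[S+]([O-])CCCCN=C=S`: 3850 nM
Compound 2 `[O-][S+](CCCCN=C=S)C1CCCC1`: 3140 nM
Compound 3 `[O-][S+](CCCCN=C=S)c1ccccc1`: 4530 nM

These three values lie close together. Compound 1, at 3850 nM, sits within the usual scatter of repeated measurements from both compound 2 and compound 3, so the data do not separate the three compounds. Each carries a different group on the sulfur, yet the read-out stays in one narrow band.

The next compound to be tested is compound 4 `[O-][S+](CCCCN=C=S)Cc1ccco1`. Relative to compound 1, it has furan-2-yl in place of methyl on a saturated chain carbon bound to a sulfur. Going by the values given here, no measured compound here contains this group, so the expectation has to lean on its neighbours. Compound 2 at 3140 nM and compound 3 at 4530 nM both show that replacing the group on the sulfur of compound 1 has left the value within the scatter so far. On that basis, no change beyond the scatter is expected in this assay, and the estimated step of a 1.1-fold lower number from compound 1 to compound 4 (0.04 log units; within the scatter) is small, with no firm direction.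

For compound 4 the expected value is 3500 nM, with an estimated range from 1800 nM to 6500 nM.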

Compound 4, half-maximal inhibitory concentration: 3470 nM
Estimate against measurement, compound 4: 1.0-fold (0.00 log units) above, and the stated range covers the measured number.
By their numbers in this assay, from the lowest: compounds 2, 4, 1 and 3 (each within the scatter of the next).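

Going by these compounds alone, this is the first pair in the set that differs in one place only, so it gives a direct reading of a change on the saturated chain carbon bound to a sulfur. In this assay, furan-2-yl in place of methyl gives a 1.1-fold lower number from compound 1 to compound 4 (0.05 log units; within the scatter), so replacing 1 heavy atom with 5, adding a five-membered aromatic ring and adding 1 hydrogen-bond acceptor does not separate the two compounds. Nothing available explains why the number holds steady through this change.

The result says little about which part of these compounds matters for the effect on the cells, since all four values still lie close together and no change shown so far moves the number beyond the scatter. Whether an amine or a carboxylic acid at this same place, or a longer chain in the shared core, would leave the number equally undisturbed remains an open question.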